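A few compounds are considered here, and "the series" means these few. Any claim that something is new, unique, unknown or untested is made for them only; others in the source may bear on it.

Of the compounds shown here, two have been measured so far in a functional assay on CHO cells for agonist activity at prostaglandin E2 receptor EP2 subtype (Homo sapiens), read by HTRF and cAMP accumulation, with a stated time of 30 min; on this read-out higher numbers stand for an effect only at larger amounts of compound and lower numbers for an effect already at smaller amounts. Compound 1 `O=C(O)c1csc([C@H]2CC[C@@H]3[C@@H](COc4ccc(C(F)(F)F)cc4)[C@H](O)C[C@@H]3O2)n1` gives 13 nM in this assay, the higher of the two numbers at hand. Compound 2 `O=C(O)c1csc([C@H]2CC[C@@H]3[C@@H](/C=C/[C@@H](O)COc4ccccc4)[C@H](O)C[C@@H]3O2)n1` gives 7.9 nM in this assay; the gap between compound 1 and compound 2 lies within the usual scatter of repeated measurements, so the two stand level rather than apart. Compound 3 `Cc1ccc(OC[C@@H]2[C@H]3CC[C@H](c4nc(C(=O)O)cs4)O[C@H]3C[C@H]2O)cc1` has not yet been measured. It differs from compound 1 in a single place: methyl in place of trifluoromethyl on an aromatic carbon of the six-membered aromatic ring of carbon only, para to a large group. Going by the values given here, no measured pair shows this exchange, and the two numbers available give no indication of how much weight this ring substituent carries. The expectation for compound 3 in this assay is therefore a step of modest size from compound 1, if any, with a slight lean toward a higher number. The estimated step is a 1.7-fold higher number from compound 1 to compound 3 (0.23 log units; within the scatter). Compound 3 is expected to give about 22 nM in this assay, within a range from 7 nM to 70 nM.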

Compound 3, half-maximal effective concentration: 27 nM
Estimate against measurement, compound 3: 1.2-fold (0.09 log units) below, within the range that was stated.
By their numbers in this assay, from the lowest: compounds 2 and 1 (each within the scatter of the next); then compound 3.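

In this assay, going by these compounds alone, the exchange of trifluoromethyl for methyl on an aromatic carbon, para to a large group, gives a 2.1-fold higher number from compound 1 to compound 3 (0.32 log units; beyond the scatter) and is the first change at this position that can be read from a matched pair. The step is modest, but it shows that the substituent at this place is not without weight on this read-out, since 4-(trifluoromethyl)phenyl and 4-methylphenyl can be told apart, if only narrowly. The group that leaves and the group that enters differ in heavy atoms but not in hydrogen-bond donors, hydrogen-bond acceptors or net charge, and no independent data bear on why the number moves.

The compounds shown leave open how a plain hydrogen, a chlorine atom or a methoxy group at this place would compare with trifluoromethyl and methyl, so two substituents cannot yet define a trend. Within the data shown here, they also leave open whether the same exchange would give a step of similar size on a different side chain, such as the one carried by compound 2.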